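The source may hold more compounds than are shown below. What is called first, only, known or untested is meant among the compounds shown, and "the series" means these compounds.

Three compounds were measured in a functional assay on cells for positive allosteric modulation of metabotropic glutamate receptor 2 (Homo sapiens), read by fluorescence and calcium flux, with a stated time of 30 min; on this read-out higher numbers stand for an effect only at larger amounts of compound and lower numbers for an effect already at smaller amounts. Compound 1 `Brc1ccc(Cn2nnc3c(Br)cccc32)cn1` gives 210 nM in this assay, and compound 2 `Clc1ccc(Cn2nnc3c(Br)cccc32)cn1` gives 290 nM. The two differ at one place, (chloro in place of bromo on an aromatic carbon), and the step of a 1.4-fold higher number from compound 1 to compound 2 (0.14 log units; within the scatter). Compound 3 `Brc1cccc2c1nnn2CC1CC1` gives 70 nM in this assay, the lowest of the three numbers; its core is not the same as the core of compound 1, and the difference between the two cores is not broken down here.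

Compound 4 `Clc1cccc2c1nnn2CC1CC1` has not been measured. It differs from compound 3 in one place, (chloro in place of bromo on an aromatic carbon). Going by the values given here, this is the same kind of change as the one from compound 1 to compound 2, but not the same: in compound 1 the change sits on an aromatic carbon of a six-membered aromatic ring with one nitrogen, next to the ring nitrogen and para to a large group, whereas in compound 3 it sits on an aromatic carbon of a six-membered aromatic ring of carbon only, part of a fused system of two rings, ortho and meta to a fused ring.

The expectation for compound 4 rests on a single precedent: because the step of a 1.4-fold higher number from compound 1 to compound 2 (0.14 log units; within the scatter) stayed within the scatter, a step of similar size, a 1.4-fold higher number from compound 3 to compound 4 (0.13 log units; within the scatter), is expected in this assay, which is also the direction a single observed step gives. Compound 4 is therefore estimated at 95 nM in this assay, with a range from 45 nM to 200 nM.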

Compound 4, half-maximal effective concentration: 90 nM
Compound 4: the middle estimate sits 1.1-fold (0.02 log units) above what was measured; low and high end bracket the measured number.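

In this assay, chloro in place of bromo on an aromatic carbon gives a 1.3-fold higher number from compound 3 to compound 4 (0.11 log units; within the scatter), and this step agrees with the earlier one on the other core: the same change on two cores in this assay, a 1.4-fold higher number (0.14 log units; within the scatter) from compound 1 to compound 2 and a 1.3-fold higher number (0.11 log units; within the scatter) from compound 3 to compound 4, 1.1-fold (0.03 log units) apart, within the scatter of two such steps In the two cases shown, then, the exchange carried over from one core to the other without a step beyond the scatter, even though it sits on a six-membered aromatic ring with one nitrogen in the first pair and on a six-membered aromatic ring of carbon only, part of a fused system, in the second. This rests on just two pairs, so it does not show that the exchange would behave alike on any further core, and, with both steps within the scatter, it gives no ground for preferring either halogen or for saying why the two steps agree.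

The compounds shown leave open what other groups would do at this place on the aromatic carbon, such as fluoro, methyl, methoxy, nitrile or an amine, since only bromo and chloro appear there. They also leave open how a longer chain or a carboxylic acid would fare in place of the cyclopropyl-bearing side chain of compound 3 and compound 4.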